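Hexyloxy in Place of Benzylamino: Cytotoxicity Outlook

The compounds below may be only part of what the source reports. "The series", "measured", "known", "first", "only" and "open" are said of these compounds alone.

Measured compounds:
compound 1, `Nc1nc(NCc2ccccc2)c2ncn(/C=C3/CC3(CO)CO)c2n1` — > 300000 nM
compound 2, `CCOc1nc(N)nc2c1ncn2/C=C1/CC1(CO)CO` — > 300000 nM

Both compounds were tested in an ADME assay on HFF cells (Homo sapiens) for cytotoxicity, with a stated time of 8 days; a lower number here means that less compound is tolerated, a higher number that more compound is tolerated. In this assay compound 1 gives > 300000 nM, which is a limit of the assay and not a number. Compound 2 likewise gives > 300000 nM, again a limit. For the measured compounds named here, compound 1 therefore stands only at a limit, and the single further value shown is a limit as well; both sit at the limit of > 300000 nM in this assay, at which 2 of the 2 values shown sit. Going by the values given here, the one measured step, a step that the two limits leave unreadable from compound 1 to compound 2, consists of ethoxy in place of benzylamino on an aromatic carbon, and its size cannot be read because both of its ends are limits.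

Compound 3 `CCCCCCOc1nc(N)nc2c1ncn2/C=C1/CC1(CO)CO` has not yet been measured in this assay. It differs from compound 1 by hexyloxy in place of benzylamino on an aromatic carbon. Among the compounds with values here, the step to compound 2 is the only measured change at the same aromatic carbon, and it bears on compound 3 in that replacing benzylamino with an alkoxy group left the value at the limit. On that ground compound 3 is expected to stay at the limit too, with an expected step of a number no higher from compound 1 to compound 3 (the limit leaves the size open). The estimate for compound 3 is 300000 nM, in a range from 100000 nM to 1000000 nM.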

Compound 3, half-maximal cytotoxic concentration: > 200000 nM
Compound 3: only a limit was reported; the forecaster's own chance of this, stated with the estimate: 75%; the middle value lies beyond the limit too.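

In this assay compound 3 gives > 200000 nM, which is a limit of the assay and not a number. Compound 1 and compound 2 also stand only at limits, and the steps from each of them to compound 3 cannot be read. The compounds shown leave open whether benzylamino, ethoxy or hexyloxy on the shared core makes any difference in this assay.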